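Replacing the aromatic ring with cycloheptyl in compound 4

The source may hold more compounds than are shown below. What is called first, only, known or untested is meant among the compounds shown, and "the series" means these compounds.

Compound 2 `Cc1ccc(C2(c3ccc(O)cc3)C(=O)Nc3c2ccc(F)c3F)cc1` gives the lowest number among the measured values in a functional assay on PC-3 cells (Homo sapiens) for cytotoxicity, read by WST assay, with a stated time of 72 h (on this read-out lower numbers stand for stronger inhibition and higher numbers for weaker inhibition), with 0.8 nM. Compound 1 `O=C1Nc2c(ccc(F)c2F)C1(c1ccc(O)cc1)c1ccc(F)cc1` gives 8.6 nM, so that an 11-fold lower number from compound 1 to compound 2 (1.03 log units; beyond the scatter). Compound 3 `CCCC1(c2ccc(O)cc2)C(=O)Nc2c1ccc(F)c2F` gives > 1000 nM, which is a limit of the assay rather than a number. Compound 4 `O=C1Nc2c(ccc(F)c2F)C1(c1ccc(O)cc1)C1CCCCCC1` differs from compound 2 by cycloheptyl in place of 4-methylphenyl on a saturated ring carbon. Going by the values given here, the steps that bear on this change are an at least 1200-fold higher number from compound 2 to compound 3 (3.09 log units; beyond the scatter) and an at least 110-fold higher number from compound 1 to compound 3 (2.06 log units; beyond the scatter); both swap the aromatic ring on that carbon for a non-aromatic group and both end in much weaker inhibition. A large rise in the number is therefore expected for compound 4, a 310-fold higher number from compound 2 to compound 4 (2.49 log units; beyond the scatter). Compound 4 is estimated at 250 nM, within a range from 30 nM to 1500 nM.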

Compound 4, half-maximal inhibitory concentration: 12 nM
Beside the measured number, compound 4's estimate is 21-fold (1.32 log units) above it, and the stated range ends above it.
By their numbers in this assay, from the lowest: compound 2; then compounds 1 and 4 (each within the scatter of the next). At a limit, above all of these: compound 3.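

An aromatic ring on this saturated ring carbon is not required for a low number: cycloheptyl and 4-fluorophenyl give values within the usual scatter of each other (a 1.4-fold higher number from compound 1 to compound 4 (0.14 log units; within the scatter)). The 4-methylphenyl group still keeps a clear lead over cycloheptyl (a 15-fold higher number from compound 2 to compound 4 (1.18 log units; beyond the scatter)). Carbon count alone does not set the outcome, but a non-aromatic ring does far better than the propyl chain, in a step that starts from a limit of the assay rather than a number (an at least 83-fold lower number from compound 3 to compound 4 (1.92 log units; beyond the scatter)). From the compounds shown here alone, whether a smaller ring such as cyclopentyl, or a longer chain such as hexyl, would behave like cycloheptyl or like propyl stays open. So does the effect of an amine on the cycloheptyl ring.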